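Piperidin-1-yl for diethylamino: notes on the series

This account rests on a few compounds, and the source may have more. Where it says the series, first, only, none or still open, it means among the compounds named here.

Measured so far in a functional assay on MGC-803 cells (Homo sapiens) for cytotoxicity, read by MTT assay, with a stated time of 48 h; a lower number here means a stronger inhibitor, a higher number a weaker inhibitor
- compound 1 (`CC1=NN(C(=O)c2ccc(C)cc2)C(c2ccccc2O)C1`) gives 26300 nM
- compound 2 (`CCN(CC)CC(=O)N1N=C(C)CC1c1ccccc1O`) gives 39800 nM
- compound 3 (`CC1=NN(C(=O)CN2CCCCC2)C(c2ccccc2O)C1`) awaits measurement

Among the measured compounds shown here, compound 2 (39800 nM) cannot be separated from compound 1 (26300 nM), the only other number available. Compound 3 carries piperidin-1-yl in place of diethylamino on a saturated chain carbon bound to a carbonyl carbon. For the measured compounds named here, one measured step bears on this: the exchange of 4-methylphenyl for (diethylamino)methyl on a carbonyl carbon (a 1.5-fold higher number from compound 1 to compound 2 (0.18 log units; within the scatter)). That exchange stayed within the scatter, so the smaller exchange here is expected to do likewise. The estimated step (a 1.1-fold lower number from compound 2 to compound 3 (0.06 log units; within the scatter)) is expected to stay within the scatter in this assay, with no direction favoured. The expected value for compound 3 is 35000 nM within a range of 15000 nM to 80000 nM as estimated here.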

Compound 3, half-maximal inhibitory concentration: 4310 nM
The estimate for compound 3 lay 8.1-fold (0.91 log units) above the measured number; the measured number lies below the stated range.
By their numbers in this assay, from the lowest: compound 3; then compounds 1 and 2 (each within the scatter of the next).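

In this assay, piperidin-1-yl in place of diethylamino on a saturated chain carbon bound to a carbonyl carbon gives a step beyond the scatter (a 9.2-fold lower number from compound 2 to compound 3 (0.97 log units; beyond the scatter)), so this position responds to a change that the earlier pair could not reveal. Replacing 4-methylphenyl on a carbonyl carbon therefore has two outcomes in this small set: (diethylamino)methyl stays within the scatter (a 1.5-fold higher number from compound 1 to compound 2 (0.18 log units; within the scatter)), whereas (piperidin-1-yl)methyl goes beyond it (a 6.1-fold lower number from compound 1 to compound 3 (0.79 log units; beyond the scatter)). No measurement available here accounts for the difference between the two groups.

Three compounds do not show whether the six-membered ring is needed or whether another cyclic amine, such as pyrrolidin-1-yl or morpholin-4-yl, would serve equally well. Going by these compounds, the effect of a longer chain between the carbonyl and the piperidin-1-yl group also remains open.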